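Shared Core, a Bulkier Chain: Estimating Compound 4

The compounds below may be only part of what the source reports. "The series", "measured", "known", "first", "only" and "open" are said of these compounds alone.

Of the compounds shown here, three built on one shared core have been measured in a physicochemical assay for acid dissociation. Compound 1 `Brc1ccc(Br)c(N(CC2CC2)C2=NCCN2)c1` gives 11. Compound 2 `Brc1cccc(N(CC2CC2)C2=NCCN2)c1Br` gives 11.1. Compound 3 `CC(C)CN(C1=NCCN1)c1c(Br)cccc1Br` gives 11. On these numbers compound 3 stands level with compound 1 at the digits printed, the two together the lowest of the three; compound 2 sits a little higher, but that gap lies within the usual scatter, so no order can be read from it. Within the data shown here, the three compounds differ in more than one place from one another, so no single step can be traced among them; what the set shows is that all three acid dissociation constants fall within the scatter of each other.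

Compound 4 `Brc1cccc(Br)c1N(CC1CCCC1)C1=NCCN1` has not yet been measured. Compared with compound 3 it carries a different group on the saturated chain carbon bound to a nitrogen on an aromatic ring: cyclopentyl in place of isopropyl on a saturated chain carbon bound to a nitrogen on an aromatic ring

Since the three measured compounds gave no difference beyond the scatter, compound 4 is expected to behave much like compound 3, and the step of no change at the digits printed from compound 3 to compound 4 (within the scatter) is expected to be none beyond the scatter. In this assay compound 4 is therefore estimated at 11, with a likely range from 10.7 to 11.3.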

Compound 4, acid dissociation constant: 10.9
Beside the measured number, compound 4's estimate is 0.10 log units above it; the range from low to high includes it.
By their numbers in this assay, from the lowest: compounds 4, 1, 3 and 2 (each within the scatter of the next).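

This comparison gives the set its first change in one place: with the rest of compound 3 kept, cyclopentyl takes the place of isopropyl on a saturated chain carbon bound to a nitrogen on an aromatic ring, and this assay shows a number 0.10 log units lower from compound 3 to compound 4 (within the scatter) as the result. At this position, then, going from a group of 3 carbon atoms with no ring to one of 5 carbon atoms with a five-membered non-aromatic ring leaves the read-out within the scatter, and the same holds when the difference is read one bond further out, as isobutyl to cyclopentylmethyl. The data offer no measured account of why the read-out stays within the scatter across this change.

Every group shown at this place is built of carbon only, so the compounds leave open whether an amine, a carboxylic acid or a longer chain there would shift the read-out beyond the scatter. They also leave open how the cyclopropylmethyl group of compound 1 and compound 2 compares with cyclopentylmethyl, since neither compound differs from compound 4 in this one place alone.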